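The source may hold more compounds than are shown below. What is called first, only, known or untested is meant among the compounds shown, and "the series" means these compounds.

The measured compounds:
compound 1, `C[C@H](NC(=O)c1nnn(Cc2cccc(C(F)(F)F)c2)c1C(F)(F)F)c1ccc(C(=O)O)cc1`; compound 2, `C[C@H](NC(=O)c1c(C(F)(F)F)nnn1Cc1cccc(C(F)(F)F)c1)c1ccc(C(=O)O)cc1`; compound 3, `C[C@H](NC(=O)c1c(-c2ccccc2)nnn1Cc1cccc(C(F)(F)F)c1)c1ccc(C(=O)O)cc1`.

In a functional assay on CHO cells for antagonist activity at prostaglandin E2 receptor EP4 subtype (Homo sapiens), read by calcium flux, with a stated time of 15 min (a lower number here means a stronger inhibitor, a higher number a weaker inhibitor), compound 1 gives > 10000 nM, which is a limit of the assay rather than a number. In this assay compound 2 gives 1970 nM. Compound 3 gives 23 nM in this assay, the lowest of the two numbers shown; its nearest neighbour is compound 2, and the two are separated by an 86-fold lower number from compound 2 to compound 3 (1.93 log units; beyond the scatter). Among the compounds with values here, that step exchanges the group on an aromatic carbon of the shared core and is the only step measured here.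

Compound 4, `C[C@H](NC(=O)c1c(-c2ccccc2)nnn1CCOc1ccc(C(F)(F)F)cc1)c1ccc(C(=O)O)cc1`, differs from compound 3 at another place: (4-(trifluoromethyl)phenoxy)methyl in place of 3-(trifluoromethyl)phenyl on a saturated chain carbon bound to an aromatic nitrogen. Within the data shown here, no measured step touches that position; the one known step offers no direct guide to the size or direction of this change. The expectation is a modest shift, with compound 4 estimated to sit somewhat higher than compound 3 in this assay, a step of a 2.6-fold higher number from compound 3 to compound 4 (0.42 log units; beyond the scatter). Compound 4 is expected to give 60 nM in this assay, with a range from 15 nM to 400 nM.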

Compound 4, half-maximal inhibitory concentration: 49.1 nM
For compound 4 the middle estimate is 1.2-fold (0.09 log units) above the measured one, within the range that was stated.
By their numbers in this assay, from the lowest: compound 3; then compound 4; then compound 2. At a limit, above all of these: compound 1.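

Within the data shown here, this is the first measured change on the saturated chain carbon bound to an aromatic nitrogen, and in this assay replacing 3-(trifluoromethyl)phenyl with (4-(trifluoromethyl)phenoxy)methyl gives a 2.1-fold higher number from compound 3 to compound 4 (0.33 log units; beyond the scatter). The position therefore accepts a different group, one with a hydrogen-bond acceptor where the old group had none, at a real but modest cost, far smaller than the change on an aromatic carbon, an 86-fold lower number from compound 2 to compound 3 (1.93 log units; beyond the scatter). Nothing measured here explains why the number rises.

The change alters the link to the ring and the place of the trifluoromethyl together, so the compounds shown cannot separate the two. As far as these compounds go, how an amine in place of the oxygen, or a 3-(trifluoromethyl)phenoxy group on the same chain, would compare remains open.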